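The source may hold more compounds than are shown below. What is called first, only, known or untested is meant among the compounds shown, and "the series" means these compounds.

Measured compounds:
Compound 1 `COc1ccc2sc(/C=C\c3cc(OC)c(OC)c(OC)c3)cc2c1` — for compound 1 the result in a functional assay on MES-SA/Dx5 cells (Homo sapiens) for antiproliferative activity, with a stated time of 72 h (a higher number here means a weaker inhibitor, a lower number a stronger inhibitor), is "not determined" (no result reported).
Compound 2 `COc1ccc(/C=C\c2cc(OC)c(OC)c(OC)c2)s1` — compound 2 gives 75 nM in this assay.

Compound 1 therefore stands nowhere on the numbers shown: it has no value in this assay, and no step between measured compounds is available. Compound 3 `COc1cc(/C=C\c2cc3ccccc3s2)cc(OC)c1OC` is reached from compound 1 by one change, (hydrogen in place of methoxy on an aromatic carbon). Within the data shown here, with no number for compound 1, no size or direction of step in this assay can be stated, and the only anchor is compound 2. Compound 3 is expected to land near that anchor because compound 2 shows 75 nM, giving an estimate of 60 nM with a range of 15 nM to 250 nM.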

Compound 3, half-maximal inhibitory concentration: 19 nM
Estimate against measurement, compound 3: 3.2-fold (0.50 log units) above; the measured number falls inside the stated range.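

Among these compounds, no step from compound 1 to compound 3 can be read in this assay. The compounds shown leave open what replacing methoxy with hydrogen does in this assay. No evidence bearing on this result is available.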